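The source may hold more compounds than are shown below. What is called first, only, known or untested is meant among the compounds shown, and "the series" means these compounds.

In a functional assay on MCF7 cells (Homo sapiens), read by MTT assay, with a stated time of 48 h (a higher number here means a weaker inhibitor, a lower number a stronger inhibitor), compound 1 (`CCN(CC)CCNC(=O)c1ccc(C(CC)(CC)c2ccc(OCC(O)C(C)(C)C)c(C)c2)n1CC`) gives 690 nM and compound 2 (`CCN(CC)CCCNC(=O)c1ccc(C(CC)(CC)c2ccc(OCC(O)C(C)(C)C)c(C)c2)n1CC`) gives 190 nM while compound 3 (`CCn1c(C(=O)N(CCC#N)CCC#N)ccc1C(CC)(CC)c1ccc(OCC(O)C(C)(C)C)c(C)c1`) gives 480 nM on the same shared core. Compound 3 is placed by two steps, a 1.4-fold lower number from compound 1 to compound 3 (0.16 log units; within the scatter) and a 2.5-fold higher number from compound 2 to compound 3 (0.40 log units; beyond the scatter), both made on the carbonyl carbon. The chain change alone gives a 3.6-fold lower number from compound 1 to compound 2 (0.56 log units; beyond the scatter) in this series. Compound 4 (`CCn1c(C(=O)N(C)CC(=O)O)ccc1C(CC)(CC)c1ccc(OCC(O)C(C)(C)C)c(C)c1`) alters that same carbonyl carbon through a group of 6 heavy atoms (3 carbon, 1 nitrogen, 2 oxygen; no ring) in place of a group of 9 heavy atoms (6 carbon, 3 nitrogen; no ring), on a carbonyl carbon and so carries (carboxymethyl)(methyl)amino. For the measured compounds named here, no measured compound holds this group, so the data offer no direct precedent and the uncertainty is wide. The expectation rests on the three measured compounds, where even the largest step on this carbonyl carbon, a 3.6-fold lower number from compound 1 to compound 2 (0.56 log units; beyond the scatter), stayed modest. In this assay the expected change is small, with a 1.3-fold higher number from compound 3 to compound 4 (0.10 log units; within the scatter) estimated and no shift beyond the scatter foreseen. For compound 4 the estimated value is 600 nM with an expected range of 150 nM to 2500 nM for repeated measurements.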

Compound 4, half-maximal inhibitory concentration: 25400 nM
For compound 4 the middle estimate is 42-fold (1.63 log units) below the measured one; measured number above the stated range.
By their numbers in this assay, from the lowest: compound 2; then compounds 3 and 1 (each within the scatter of the next); then compound 4.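

In this assay, for the compounds shown here, this change shows that the carbonyl carbon is not a uniformly tolerant place: the steps among the earlier compounds were modest at most, whereas (carboxymethyl)(methyl)amino brings much larger ones (a 53-fold higher number from compound 3 to compound 4 (1.72 log units; beyond the scatter)) and (a 37-fold higher number from compound 1 to compound 4 (1.57 log units; beyond the scatter)) and (a 130-fold higher number from compound 2 to compound 4 (2.13 log units; beyond the scatter)). Absence of the diethylamino end alone does not account for this, since compound 3 also lacks it yet stays within the scatter of compound 1, so the large loss appears only with the group carried by compound 4. Nothing available explains the size of this step.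

What the compounds shown leave open is whether the carboxylic acid itself goes with the loss, which a methyl ester on the same chain could test. A longer chain ending in a carboxylic acid, or a primary amide in its place, could show how far the effect extends.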